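Trimming the amide substituent in the sulfonylpiperidine series

This account rests on a few compounds, and the source may have more. Where it says the series, first, only, none or still open, it means among the compounds named here.

Among the compounds with values here, compound 2 `CCN(CC)S(=O)(=O)c1ccc(S(=O)(=O)N2CCC[C@@H](C(=O)N[C@@H]3CCN(C(=O)OC(C)(C)C)C3)C2)cc1` gives 200 nM in a functional assay on MIA PaCa-2 cells (Homo sapiens) for inhibition, read by MTT assay, with a stated time of 7 days (a lower number here means a stronger inhibitor, a higher number a weaker inhibitor), the highest of the three numbers so far; its gap to compound 3 lies within the scatter, its gap to compound 1 beyond it. Compound 1 `CC(C)c1noc(N2CCN(C(=O)[C@@H]3CCCN(S(=O)(=O)c4ccc(S(=O)(=O)C(C)C)cc4)C3)CC2)n1` gives 70 nM in this assay, and compound 3 `CCN(CC)C(=O)c1ccc(S(=O)(=O)N2CCC[C@@H](C(=O)N3CCN(c4nc(C(C)C)no4)CC3)C2)cc1` gives 100 nM. Within the data shown here, the only single-point step measured, a 1.4-fold higher number from compound 1 to compound 3 (0.15 log units; within the scatter), concerns the aromatic substituent and is within the scatter. Compound 4 `CCN(CC)S(=O)(=O)c1ccc(S(=O)(=O)N2CCC[C@@H](C(=O)NC)C2)cc1` differs from compound 2 in one place: methyl in place of 1-(tert-butoxycarbonyl)pyrrolidin-3-yl on an amide-type nitrogen. Among the measured compounds shown here, no measured step touches the amide nitrogen, and compounds 1 and 3 carry a different amide altogether, so nothing here calibrates this change directly. A far smaller group enters where a large one leaves, and on general grounds such a cut is expected to weaken inhibition rather than strengthen it, so the step of a 3.0-fold higher number from compound 2 to compound 4 (0.48 log units; beyond the scatter) is expected, with wide uncertainty in both directions. Compound 4 is therefore estimated at 600 nM in this assay, within 150 nM to 2500 nM.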

Compound 4, half-maximal inhibitory concentration: 8600 nM
Compound 4: middle estimate off by 14-fold (1.16 log units), on the low side; the whole stated range lies below it.
By their numbers in this assay, from the lowest: compounds 1, 3 and 2 (each within the scatter of the next, the first and the last beyond it); then compound 4.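

On the amide-type nitrogen, the 1-(tert-butoxycarbonyl)pyrrolidin-3-yl group cannot be cut back to methyl without a large loss of inhibition in this assay: the change gives a 43-fold higher number from compound 2 to compound 4 (1.63 log units; beyond the scatter). Within the data shown here, this is the first measured step at this position, and it shows that the amide substituent of this series is not a freely trimmable appendage, even though the aromatic substituent step of a 1.4-fold higher number from compound 1 to compound 3 (0.15 log units; within the scatter) stays within the scatter. The change removes the ring, the carbamate and the stereocentre together, and no evidence shown accounts for the loss.

The compounds shown leave open which of these parts carries the inhibition. A free pyrrolidin-3-yl amine, a cyclopentyl group or a longer alkyl chain on the same nitrogen would begin to separate them.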